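A few compounds are considered here, and "the series" means these few. Any claim that something is new, unique, unknown or untested is made for them only; others in the source may bear on it.

Measured so far in a functional assay on Raji cells (Homo sapiens); on this read-out higher numbers stand for weaker inhibition and lower numbers for stronger inhibition:
Compound 1 `CCCCCCc1cn([C@H]2C[C@@H]3OP(=O)(O)OC[C@H]3O2)c(=O)[nH]c1=O` gives only a limit, > 500 ug/mL.
Compound 3 `CCCCCc1cn([C@H]2C[C@@H]3OP(=O)(O)OC[C@H]3O2)c(=O)[nH]c1=O` gives only a limit, > 500 ug/mL.
Compound 2 `CCCCc1cn([C@H]2C[C@H](O)[C@@H](CO)O2)c(=O)[nH]c1=O` gives only a limit, > 500 ug/mL.

Compound 3 and compound 1 share a core and differ by methyl in place of hydrogen on a saturated chain carbon, five bonds along the chain from an aromatic carbon. The step that the two limits leave unreadable from compound 3 to compound 1 cannot be read, since both values are limits. Compound 2 and compound 3 have different cores; that difference is not broken down here. Compound 4 `CCCCCc1cn([C@H]2C[C@H](O)[C@@H](CO)O2)c(=O)[nH]c1=O` is compound 2 changed by methyl in place of hydrogen on a saturated chain carbon, four bonds along the chain from an aromatic carbon, the same kind of change as from compound 3 to compound 1, though the place differs: four bonds along the chain from an aromatic carbon rather than five. Among the measured compounds shown here, every measured value sits at the limit of > 500 ug/mL in this assay, at which 3 of the 3 values shown sit, so no step is readable. Compound 4 is expected to behave likewise, a step that the limit leaves unreadable from compound 2 to compound 4, because compound 2 sits at the limit of > 500 ug/mL in this assay, at which 3 of the 3 values shown sit. The estimate for compound 4 is 800 ug/mL, between 400 ug/mL and 3000 ug/mL, most likely again only a limit.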

Compound 4, concentration for 50% inhibition: 328 ug/mL
Compound 4: the middle estimate sits 2.4-fold (0.39 log units) above what was measured; the whole stated range lies above it.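

Compound 2 gives > 500 ug/mL and that is a limit. In this assay the step is an at least 1.5-fold lower number from compound 2 to compound 4 (0.18 log units; that floor lies within the scatter) so adding the methyl yields a measured number on this core, yet the smallest size this step can have stays within the scatter. The same kind of change on the core of compound 3, five bonds along the chain rather than four, cannot be read, so nothing shows that the change carries from one core to the other, and little can be compared because most values are limits: the limit of > 500 ug/mL in this assay, at which 3 of the 4 values shown sit.

From the compounds shown here alone, whether a longer chain on the core of compound 4 would lower the number further stays open. So does the effect of an amine in place of the chain.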